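Pyridinyl in Place of Chlorophenyl on the Amide-Type Nitrogen

The compounds below may be only part of what the source reports. "The series", "measured", "known", "first", "only" and "open" are said of these compounds alone.

Compound 1 `Cc1cc(NC(=O)Nc2ccccc2F)c2ccccc2n1`: > 25000 nM
Compound 2 `Cc1cc(NC(=O)Nc2cccc(Cl)c2)c2ccccc2n1`: 18000 nM

In an ADME assay on Raji cells (Homo sapiens) for cytotoxicity, with a stated time of 72 h (a lower number here means that less compound is needed, a higher number that more compound is needed for the effect), compound 1 gives only > 25000 nM, which is a limit of the assay (the limit of > 25000 nM in this assay, at which 1 of the 2 values shown sits). Among the compounds with values here, compound 2 gives 18000 nM, the only number among the values shown. On these data alone, the step of an at least 1.3-fold lower number from compound 1 to compound 2 (0.14 log units; that floor lies within the scatter) rests on that limit, so its true size stays open. Compound 3 `Cc1cc(NC(=O)Nc2cccnc2)c2ccccc2n1` differs from compound 2 by pyridin-3-yl in place of 3-chlorophenyl on an amide-type nitrogen. Within the data shown here, no measured step exchanges 3-chlorophenyl for pyridin-3-yl, and the one step available has a floor within the scatter, so a change within the scatter is expected. Compound 3 is therefore estimated at 25000 nM (range 10000 nM to 60000 nM), an expected step of a 1.4-fold higher number from compound 2 to compound 3 (0.14 log units; within the scatter).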

Compound 3, half-maximal effective concentration: > 25000 nM
Compound 3: no number, only a limit (the forecaster's own chance of this, stated with the estimate: 50%); the middle value lies on the limit itself.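

In this assay compound 3 gives > 25000 nM, which is a limit of the assay and not a number. Pyridin-3-yl in place of 3-chlorophenyl on the amide-type nitrogen gives an at least 1.3-fold higher number from compound 2 to compound 3 (0.14 log units; that floor lies within the scatter), so this is the first ring with a hetero atom at this place, and the true size of the step stays open. The step between compound 1 and compound 3 cannot be read, and compound 2 alone carries a number: the limit of > 25000 nM in this assay, at which 2 of the 3 values shown sit.

On these data alone, whether an aminopyridinyl or a carboxylic acid-bearing phenyl on this nitrogen would give a number remains open. So does how a longer chain in place of the ring would read.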